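This account rests on a few compounds, and the source may have more. Where it says the series, first, only, none or still open, it means among the compounds named here.

Measured so far: compound 1 `COc1ccc(-n2nc(C(N)=O)nc2-c2cc(OC)c(OC)c(OC)c2)cc1` with 59%; compound 2 `COc1ccc(-n2nc(C(=O)Nc3ccccc3OC)nc2-c2cc(OC)c(OC)c(OC)c2)cc1` with 57%.

Both compounds were tested in a functional assay on the whole organism for inhibition, with Rattus norvegicus as the target, read by paw edema, with stated times of 30 min and 2 h, at a dose of 0.28 mmol/kg by the oral route; a higher number here means more inhibition at the dose given (going by the name of the read-out), a lower number less inhibition. Compound 1 gives 59% and compound 2 gives 57%, and the step of a number 2 percentage points lower from compound 1 to compound 2 (within the scatter) lies within the scatter, so the two numbers cannot be told apart. Compound 3 `COc1ccc(-n2nc(C(=O)Nc3cccc(F)c3)nc2-c2cc(OC)c(OC)c(OC)c2)cc1` has not been measured. It differs from compound 2 at one place only, on an amide-type nitrogen whose other neighbour is the carbonyl carbon: 3-fluorophenyl in place of 2-methoxyphenyl on an amide-type nitrogen. Within the data shown here, the only measured step, a number 2 percentage points lower from compound 1 to compound 2 (within the scatter), put 2-methoxyphenyl in place of hydrogen on that nitrogen and changed nothing beyond the scatter. No measured step exchanges one aryl group for another at this place, so the data give no reason to expect a change here either. The step of no change at the digits printed from compound 2 to compound 3 (within the scatter) is expected to be no larger than the scatter. Compound 3 is estimated at 57%, expected to fall between 42% and 70%.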

Compound 3, a percentage reported as inhibition, in the whole organism at one dose (the size of the read-out at that dose, not a potency): 67%
The estimate for compound 3 lay 10 percentage points below the measured number; measured number inside the range.
By their numbers in this assay, from the lowest: compounds 2, 1 and 3 (each within the scatter of the next).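

In this assay, an exchange of one aryl group for another on the amide-type nitrogen gives a number 10 percentage points higher from compound 2 to compound 3 (within the scatter), and 3-fluorophenyl in place of the amide hydrogen gives a number 8 percentage points higher from compound 1 to compound 3 (within the scatter). This nitrogen therefore carries hydrogen, 2-methoxyphenyl or 3-fluorophenyl with all three numbers inside the scatter of one another, even though the group that leaves counts one hydrogen-bond acceptor and the group that enters counts none. No measurement shown here bears on why these numbers fall as they do.

The compounds shown leave open how a plain phenyl group, or a longer chain ending in an amine, would read on this nitrogen. They also leave open what a carboxylic acid in place of the whole amide would give.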